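The source may hold more compounds than are shown below. What is called first, only, known or untested is meant among the compounds shown, and "the series" means these compounds.

Measured so far in a functional assay on MGC-803 cells (Homo sapiens) for inhibition, read by MTT assay; on this read-out higher numbers stand for weaker inhibition and lower numbers for stronger inhibition:

Compound 1 `Cc1ccc(O)c(/C=N\NC(=O)c2oc3cccc(O)c3c2C)c1`: compound 1 gives 5990 nM
Compound 2 `Cc1c(C(=O)N/N=C\c2cc(Cl)cc(Cl)c2O)oc2cccc(O)c12`: compound 2 gives 4360 nM
Compound 3 `Cc1c(C(=O)N/N=C\c2ccc(O)c(O)c2O)oc2cccc(O)c12`: compound 3 gives 18100 nM

Among these three numbers compound 1 stands second highest. Its nearest neighbour is compound 2, whose number is lower, though the gap between the two lies within the scatter of repeated measurements, so the two cannot be told apart. Compound 3 is furthest away, with a higher number, and that gap lies beyond the scatter.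

The compound not yet measured is compound 4 `Cc1c(C(=O)N/N=C\c2cccc(Br)c2O)oc2cccc(O)c12`. It differs from compound 1 in one place: 3-bromo-2-hydroxyphenyl in place of 2-hydroxy-5-methylphenyl on a carbon with a double bond to nitrogen. The hydrazone carbon, the core and the rest of the molecule are unchanged.

For the measured compounds named here, no step between two measured compounds matches this change, so the expectation rests on what the three numbers show. Going by the values given here, the only measured compound carrying halogens on this ring, compound 2, gives 4360 nM, a number within the scatter of compound 1. On that basis a step of no more than modest size is expected, leaning toward a lower number, giving a 1.4-fold lower number from compound 1 to compound 4 (0.15 log units; within the scatter). Compound 4 is therefore estimated at 4200 nM, within a range from 1500 nM to 11000 nM.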

Compound 4, half-maximal inhibitory concentration: 14200 nM
Estimate against measurement, compound 4: 3.4-fold (0.53 log units) below; the measured number lies above the stated range.
By their numbers in this assay, from the lowest: compounds 2 and 1 (each within the scatter of the next); then compounds 4 and 3 (each within the scatter of the next).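

Replacing 2-hydroxy-5-methylphenyl with 3-bromo-2-hydroxyphenyl on a carbon with a double bond to nitrogen gives a 2.4-fold higher number from compound 1 to compound 4 (0.37 log units; beyond the scatter) in this assay, so inhibition at this place responds to an exchange between two groups with the same heavy-atom count. The earlier numbers left room to read halogen on this ring as harmless, but that reading does not hold as a general one: compound 2 gives 4360 nM, whereas compound 4 gives 14200 nM, which shows that the outcome depends on which halogen pattern the ring carries and not merely on the presence of a halogen. No measurement at hand bears on why the number rises with this change.

The compounds shown leave open whether the weaker inhibition of compound 4 follows from the bromine itself, from its place on the ring or from the loss of the methyl group. They also leave open how this ring would respond to a single chlorine, a methoxy group, an amine or a carboxylic acid.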